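The source may hold more compounds than are shown below. What is called first, only, known or untested is meant among the compounds shown, and "the series" means these compounds.

Measured so far:
compound 1, `O=C(Nc1cccc(-n2cc(-c3ccncc3)c(-c3ccc(Cl)c(O)c3)n2)c1)Nc1cccc(C(F)(F)F)c1`: in a functional assay on SK-MEL-28 cells (Homo sapiens) for inhibition, read by sulforhodamine B assay, with a stated time of 48 h (on this read-out lower numbers stand for stronger inhibition of growth and higher numbers for weaker inhibition of growth), compound 1 gives 4110 nM
compound 2, `COc1cc(-c2nn(-c3cccc(NC(=O)Nc4cc(C(F)(F)F)cc(C(F)(F)F)c4)c3)cc2-c2ccncc2)ccc1Cl`: in this assay compound 2 gives 851 nM

Of the two numbers, compound 2 has the lower one, and the gap to compound 1 lies beyond the usual scatter, so compound 2 is the stronger inhibitor of growth here.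

Compound 3, `O=C(Nc1cccc(-n2cc(-c3ccncc3)c(-c3ccc(Cl)c(O)c3)n2)c1)Nc1cc(C(F)(F)F)cc(C(F)(F)F)c1`, is not yet measured. It differs from compound 2 by hydrogen in place of methyl on an oxygen on an aromatic ring, reading as methoxy to hydroxy. For the measured compounds named here, no measured pair shows this change alone. Compound 1 also carries the hydroxy group, but it differs from compound 3 elsewhere too. The value of compound 1, 4110 nM, therefore gives only a loose hint that the hydroxy may sit on the weaker side.

On that basis a modest weakening is expected for compound 3, with the step of a 1.9-fold higher number from compound 2 to compound 3 (0.27 log units; within the scatter). Compound 3 is estimated at 1600 nM, within a range from 500 nM to 5000 nM.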

Compound 3, concentration for 50% growth inhibition: 796 nM
Estimate against measurement, compound 3: 2.0-fold (0.30 log units) above, within the range that was stated.
By their numbers in this assay, from the lowest: compounds 3 and 2 (each within the scatter of the next); then compound 1.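

Hydrogen in place of methyl on an oxygen on an aromatic ring gives a 1.1-fold lower number from compound 2 to compound 3 (0.03 log units; within the scatter) in this assay, so on this read-out methoxy and hydroxy cannot be told apart here, and the loose hint from compound 1 against the hydroxy does not hold. For the compounds shown here, the gap to compound 1 follows the other change instead: trifluoromethyl in place of hydrogen on an aromatic carbon gives a 5.2-fold lower number from compound 1 to compound 3 (0.71 log units; beyond the scatter) and lies beyond the scatter, which is the first clean reading of that change. Nothing at hand explains either step.

The compounds shown leave open whether a longer chain on that oxygen, or an amine in place of the hydroxy, would also leave growth inhibition level. They also leave open whether the trifluoromethyl step holds with methoxy in place of hydroxy, and whether a nitrile could stand in for the added trifluoromethyl.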